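A few compounds are considered here, and "the series" means these few. Any claim that something is new, unique, unknown or untested is made for them only; others in the source may bear on it.

Measured so far:
Compound 1 `Cc1ccc(-c2nnc(SCCCN3CCN(c4cccc(Cl)c4)CC3)[nH]2)cc1` — in a functional assay on THP-1 cells (Homo sapiens) for cytotoxicity, read by MTT assay, with a stated time of 24 h (on this read-out lower numbers stand for stronger inhibition and higher numbers for weaker inhibition), compound 1 gives > 300000 nM, which is a limit of the assay and not a number.
Compound 2 `Clc1ccc(-c2nnc(SCCCN3CCN(c4cccc(Cl)c4)CC3)[nH]2)cc1` — in this assay compound 2 gives > 300000 nM, also a limit of the assay.

Compound 2 therefore stands at the upper boundary of what this assay reports, as does compound 1. Within the data shown here, the only measured step, a step that the two limits leave unreadable from compound 1 to compound 2, cannot be sized because the limit of > 300000 nM in this assay, at which 2 of the 2 values shown sit, covers both values. Compound 3 `Clc1ccc(-c2nnc(SCCCN3CCN(c4ncccn4)CC3)[nH]2)cc1` differs from compound 2 by pyrimidin-2-yl in place of 3-chlorophenyl on an amine nitrogen in a ring. No measured step touches this part of the molecule, so nothing shown points in either direction. With both known values at the limit, the expected step of a number no higher from compound 2 to compound 3 (the limit leaves the size open) is none beyond the scatter. Compound 3 is estimated at 300000 nM, with a range from 100000 nM to 1000000 nM, most likely reported again as a limit.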

Compound 3, half-maximal inhibitory concentration: > 300000 nM
Compound 3 ended at the assay's limit; the forecaster's own chance of this, stated with the estimate: 85%; the middle value lies on the limit itself.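

Compound 3 gives > 300000 nM in this assay, which is a limit and not a number. No step can be read from compound 2 to compound 3, because both stand at the same boundary: the limit of > 300000 nM in this assay, at which 3 of the 3 values shown sit. The compounds shown leave open whether changing any of these groups shifts the value in this assay at all.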